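Aryl swap on the shared core: furan to phenyl

The source may report more compounds than this note shows. Statements on the series, on what has been measured and on what is new or still open speak of the compounds shown alone.

Among the compounds with values here, compound 1 `O=c1[nH]cnc2c1c(-c1ccoc1)cn2[C@@H]1O[C@H](CO)[C@@H](O)[C@H]1O` is the only member of the series with a number in a functional assay on HL-60 cells (Homo sapiens) for antiproliferative activity, read by XTT assay, with a stated time of 72 h; on this read-out lower numbers stand for stronger inhibition and higher numbers for weaker inhibition; compound 1 gives 6370 nM. Compound 2 `Nc1nc2c(c(-c3ccoc3)cn2[C@@H]2O[C@H](CO)[C@@H](O)[C@H]2O)c(=O)[nH]1` shows only a limit of the assay, > 15000 nM. Within the data shown here, the single measured step, an at least 2.3-fold higher number from compound 1 to compound 2 (0.37 log units; beyond the scatter), sits at the limit of > 15000 nM in this assay, at which 1 of the 2 values shown sits, and concerns a different part of the shared core, so no measured step bears on the change to compound 3 `O=c1[nH]cnc2c1c(-c1ccccc1)cn2[C@@H]1O[C@H](CO)[C@@H](O)[C@H]1O`, (phenyl in place of furan-3-yl on an aromatic carbon). With nothing to anchor a direction, no step beyond the scatter is expected, a 1.1-fold higher number from compound 1 to compound 3 (0.04 log units; within the scatter). Compound 3 is estimated at 7000 nM, within a range from 2500 nM to 20000 nM.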

Compound 3, half-maximal inhibitory concentration: > 20000 nM
Compound 3 was reported as a limit (the forecaster's own chance of this, stated with the estimate: 25%); at least 2.8-fold (0.45 log units) between middle value and limit.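

Within the data shown here, the first measured step at this position, on the aromatic carbon of the five-membered ring, is phenyl in place of furan-3-yl, and it gives an at least 3.1-fold higher number from compound 1 to compound 3 (0.49 log units; beyond the scatter) in this assay. Furan-3-yl therefore cannot be exchanged for phenyl here without a loss beyond the scatter. The value of compound 3 is a limit, so the step sets only a minimum size: the limit of > 20000 nM in this assay, at which 1 of the 3 values shown sits.

Going by these compounds, how far activity falls with phenyl stays open. So does whether a thiophen-3-yl, a pyridine ring or a small amine at this position would match or improve on compound 1.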